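This account rests on a few compounds, and the source may have more. Where it says the series, first, only, none or still open, it means among the compounds named here.

Working notes on the series. Within the data shown here, compound 2 `COC(=O)C1=C(C)NC(C)=C(C(=O)OC2CCCCC2)C1c1csc(-c2ccc(Cl)cc2)n1` is the cyclohexyl ester of the shared core; in an assay on isolated protein for antagonist activity at Voltage-dependent L-type calcium channel subunit alpha-1C (Cavia porcellus), with a stated time of 15 min (a lower number here means a stronger inhibitor, a higher number a weaker inhibitor), compound 2 gives 71900 nM, the higher of the two numbers measured so far. Its nearest neighbour is compound 1 `COC(=O)C1=C(C)NC(C)=C(C(=O)OC2CCCC2)C1c1csc(-c2ccc(Cl)cc2)n1`, the cyclopentyl ester, which in this assay gives 7290 nM. Among the measured compounds shown here, the single measured step, a 9.9-fold higher number from compound 1 to compound 2 (0.99 log units; beyond the scatter), is the only one that bears on what follows.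

Compound 3 `COC(=O)C1=C(C)NC(C)=C(C(=O)OC(C)c2ccccc2)C1c1csc(-c2ccc(Cl)cc2)n1` is the next member: 1-phenylethyl in place of cyclohexyl on an oxygen next to a carbonyl group. The change keeps the ester oxygen and the carbonyl untouched and exchanges the whole cyclohexyl for 1-phenylethyl. For the measured compounds named here, no measured pair carries an aromatic ring at this oxygen, so the direction has to be read from the one step alone, which shows that this assay is sensitive to what sits on that oxygen, with the cyclopentyl compound 1 at 7290 nM well apart from compound 2. The working expectation is a step of about a 2.9-fold lower number from compound 2 to compound 3 (0.46 log units; beyond the scatter), with either direction possible and only a weak lean towards a lower number. Compound 3 is therefore estimated at 25000 nM in this assay, with a range from 6000 nM to 100000 nM.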

Compound 3, half-maximal inhibitory concentration: 7620 nM
For compound 3 the middle estimate is 3.3-fold (0.52 log units) above the measured one; measured number inside the range.
By their numbers in this assay, from the lowest: compounds 1 and 3 (each within the scatter of the next); then compound 2.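

In this assay, among these compounds, an aromatic ring on this oxygen next to a carbonyl group is tolerated as well as cyclopentyl, and the exchange of cyclohexyl for 1-phenylethyl gives a 9.4-fold lower number from compound 2 to compound 3 (0.97 log units; beyond the scatter) so the single earlier step was not a general penalty for a larger group at this position. Among the compounds shown here, the comparison of the other two esters gives a 1.0-fold higher number from compound 1 to compound 3 (0.02 log units; within the scatter) which leaves cyclopentyl and 1-phenylethyl indistinguishable here and makes compound 2 the one member set apart, with its steps to both others beyond the scatter. The 1-phenylethyl group has more heavy atoms than cyclohexyl yet belongs with the lower numbers, so heavy-atom count alone does not order these three esters, and no independent measurement accounts for the position of cyclohexyl.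

The compounds shown do not separate the contribution of the phenyl ring from that of the branched carbon carrying it, a question that benzyl and 2-phenylethyl esters would address. Also open, as far as these compounds go, is how this assay responds to a longer straight chain or to an ester bearing an amine, such as 2-(dimethylamino)ethyl, on the same oxygen.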